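Hydrogen in Place of Methyl on a Ring Nitrogen

The source may hold more compounds than are shown below. What is called first, only, known or untested is meant among the compounds shown, and "the series" means these compounds.

In an assay on isolated protein for inhibition of tyrosine-protein kinase receptor UFO (Homo sapiens), read by LC-MS (a higher number here means a weaker inhibitor, a lower number a stronger inhibitor), compound 3 `Cc1cc(-c2c(C)nn(C)c2C)ccc1-c1nnc(N(C)Cc2ccc3nccn3c2)o1` gives 79.4 nM, the lowest of the three numbers seen so far. Compound 1 `Cc1nn(C)c(C)c1-c1ccc(-c2nnc(N(C)Cc3ccc4nccn4c3)o2)c(F)c1` gives 1260 nM and compound 2 `COc1cc(-c2c(C)nn(C)c2C)ccc1-c1nnc(N(C)Cc2ccc3nccn3c2)o1` gives 794 nM; the steps of a 16-fold lower number from compound 1 to compound 3 (1.20 log units; beyond the scatter) and a 10-fold lower number from compound 2 to compound 3 (1.00 log units; beyond the scatter) lie beyond the scatter, while a 1.6-fold lower number from compound 1 to compound 2 (0.20 log units; within the scatter) does not. Compound 4 `Cc1cc(-c2c(C)n[nH]c2C)ccc1-c1nnc(N(C)Cc2ccc3nccn3c2)o1` differs from compound 3 by hydrogen in place of methyl on an aromatic nitrogen. None of the three measured steps touches this ring nitrogen; all three concern the aromatic carbon that carries fluoro, methoxy or methyl, so they give no direct guide. Going by the values given here, with no comparable step in this assay, relative to compound 3 the number for compound 4 is expected to change only modestly, a 1.4-fold higher number from compound 3 to compound 4 (0.14 log units; within the scatter). The estimate for compound 4 is 110 nM, with a range from 30 nM to 400 nM.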

Compound 4, half-maximal inhibitory concentration: 5010 nM
Estimate against measurement, compound 4: 46-fold (1.66 log units) below, outside the stated range (above it).
By their numbers in this assay, from the lowest: compound 3; then compounds 2 and 1 (each within the scatter of the next); then compound 4.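

In this assay, the methyl on the aromatic nitrogen of the 1,3,5-trimethyl-1H-pyrazol-4-yl group proves to matter: going to 3,5-dimethyl-1H-pyrazol-4-yl gives a 63-fold higher number from compound 3 to compound 4 (1.80 log units; beyond the scatter). This ring nitrogen is therefore a sensitive position, where losing a single carbon atom leaves a much weaker inhibitor. Nothing measured here bears on the reason for this rise. From the compounds shown here alone, whether an ethyl group or a longer chain on this nitrogen would keep the strength of compound 3 remains open. So does whether the same change would cost as much with fluoro or methoxy on the aromatic carbon.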